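The source may report more compounds than this note shows. Statements on the series, on what has been measured and on what is new or still open speak of the compounds shown alone.

Measured so far:
compound 1, `Cc1nc(SCC(=O)Nc2nc(-c3ccc(Cl)cc3)cs2)n(Nc2ccccc2)c1C`: 15400 nM
compound 2, `Cc1ccc(Nn2c(SCC(=O)Nc3nc(-c4ccccc4)cs3)nc(C)c2C)cc1`: 28200 nM

Both numbers come from a functional assay on HT-29 cells (Homo sapiens) for antiproliferative activity, read by sulforhodamine B assay, with a stated time of 48 h; on this read-out lower numbers stand for stronger inhibition of growth and higher numbers for weaker inhibition of growth. In this assay compound 1 gives 15400 nM and compound 2 gives 28200 nM; compound 1 has the lower of the two numbers, but the two values lie within the usual scatter of each other, so nothing separates them with confidence. Compound 3, `COc1ccc(Nn2c(SCC(=O)Nc3nc(-c4ccc(Cl)cc4)cs3)nc(C)c2C)cc1`, has not yet been measured in this assay. It differs from compound 1 by methoxy in place of hydrogen on an aromatic carbon, turning the anilino group into a (4-methoxyphenyl)amino group. Among the compounds with values here, no pair of measured compounds differs by this change alone, so the size of the step cannot be read from the data; the expectation is a step no larger than the scatter, in no fixed direction. The expected step is a 1.2-fold higher number from compound 1 to compound 3 (0.07 log units; within the scatter). Compound 3 is therefore expected to give about 18000 nM, with a plausible range from 7000 nM to 45000 nM.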

Compound 3, concentration for total growth inhibition: 50400 nM
Compound 3: middle estimate off by 2.8-fold (0.45 log units), on the low side, outside the stated range (above it).
By their numbers in this assay, from the lowest: compounds 1, 2 and 3 (each within the scatter of the next, the first and the last beyond it).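

In this assay, within the data shown here, methoxy in place of hydrogen on this aromatic carbon, para to a large group, gives a 3.3-fold higher number from compound 1 to compound 3 (0.51 log units; beyond the scatter), the first step here that changes one place only. Turning the anilino group into a (4-methoxyphenyl)amino group therefore moves the number beyond the usual scatter, towards weaker inhibition of growth, so this position is not indifferent to what sits on it, at least on the core of compound 1. Nothing measured here bears on the reason for this step.

One step cannot show whether the shift belongs to methoxy itself or would follow from any group at this place. On these data alone, how a fluorine atom, a hydroxy group or a longer ethoxy chain on the same carbon would compare with compound 1 stays open.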